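Amide aryl swap on the shared core

The source may hold more compounds than are shown below. What is called first, only, known or untested is meant among the compounds shown, and "the series" means these compounds.

Compound 1 `O=C(COc1ccc2oc(-c3ccccc3)cc(=O)c2c1)Nc1ccc2ccccc2c1` carries a naphthalen-2-yl on the amide nitrogen. For the measured compounds named here, in a functional assay on NPC-TW01 cells (Homo sapiens) for antiproliferative activity, read by MTT assay, with a stated time of 72 h (a lower number here means a stronger inhibitor of growth, a higher number a weaker inhibitor of growth), compound 1 gives 6750 nM, the only full number in the set. Compound 2 `O=C(COc1ccc2c(=O)cc(-c3ccccc3)oc2c1)Nc1ccc2ccccc2c1`, which differs in the arrangement of the shared core, reaches in this assay only the assay limit of > 10000 nM, as seen in the limit of > 10000 nM in this assay, at which 1 of the 2 values shown sits. Compound 3 `O=C(COc1ccc2oc(-c3ccccc3)cc(=O)c2c1)Nc1ccc(F)cc1` follows the change (4-fluorophenyl in place of naphthalen-2-yl on an amide-type nitrogen). Going by the values given here, no measured pair covers this move, so its size in this assay is open. A modest loss of growth inhibition is expected, as a 1.3-fold higher number from compound 1 to compound 3 (0.12 log units; within the scatter). Compound 3 is therefore expected near 9000 nM, within 3000 nM to 27000 nM.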

Compound 3, concentration for 50% growth inhibition: 740 nM
For compound 3 the middle estimate is 12-fold (1.09 log units) above the measured one, outside the stated range (below it).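

In this assay the swap to 4-fluorophenyl gives a 9.1-fold lower number from compound 1 to compound 3 (0.96 log units; beyond the scatter) and so shows that the group on the amide-type nitrogen matters on this core, with the single fluorinated ring ahead of naphthalen-2-yl. No measurement shown explains this step.

As far as these compounds go, whether the gain comes from the fluorine or from the loss of the second ring stays open, and a plain phenyl would separate the two. Also open, from the compounds shown here alone, are a 4-carboxylic acid or a 4-amino group on that ring, and the same swap on the core of compound 2.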